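The source may hold more compounds than are shown below. What is called first, only, known or untested is meant among the compounds shown, and "the series" means these compounds.

Measured so far in an ADME assay on HUVEC cells (Homo sapiens) for antiproliferative activity, read by MTT assay, with a stated time of 48 h; on this read-out higher numbers stand for weaker inhibition and lower numbers for stronger inhibition:

Compound 1 `CCOc1ccc(-n2nncc2CN2C(=O)C3(C(C#N)=C(N)Oc4c(N)cc5nc6ccccc6nc5c43)c3ccccc32)cc1`: in this assay compound 1 gives > 50000 nM, which is a limit of the assay rather than a number.
Compound 2 `Cc1ccc(-n2nncc2CN2C(=O)C3(C(C#N)=C(N)Oc4c(N)cc5nc6ccccc6nc5c43)c3ccccc32)cc1C`: in this assay compound 2 gives > 50000 nM, again a limit of the assay and not a number.

Compound 2 therefore stands at the limit of > 50000 nM in this assay, at which 2 of the 2 values shown sit, the same point at which compound 1 sits. Going by the values given here, the single step between measured compounds, a step that the two limits leave unreadable from compound 1 to compound 2, is one that the two limits leave unreadable, so its size and direction are unknown.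

Compound 3 `N#CC1=C(N)Oc2c(N)cc3nc4ccccc4nc3c2C12C(=O)N(Cc1cnnn1-c1c(Cl)cc(Cl)cc1Cl)c1ccccc12` is the next member to be run in this assay. Relative to compound 2 the change is 2,4,6-trichlorophenyl in place of 3,4-dimethylphenyl on an aromatic nitrogen.

Among the compounds with values here, only the step from compound 1 to compound 2 bears on this change, and it carries no readable size. With both measured values sitting at the limit of > 50000 nM in this assay, at which 2 of the 2 values shown sit, no step beyond the scatter in either direction can be read out of the numbers shown, and the default expectation for the new group is another value at the limit. Compound 3 is accordingly estimated at 60000 nM in this assay, with a range from 20000 nM to 200000 nM; the step this expectation implies is a step that the limit leaves unreadable from compound 2 to compound 3.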

Compound 3, half-maximal inhibitory concentration: 18300 nM
Beside the measured number, compound 3's estimate is 3.3-fold (0.52 log units) above it; measured number outside the range, below it.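

In this assay, the aryl group on the aromatic nitrogen of the five-membered ring with 3 nitrogen proves able to shift the read-out: 2,4,6-trichlorophenyl in place of 3,4-dimethylphenyl gives an at least 2.7-fold lower number from compound 2 to compound 3 (0.43 log units; beyond the scatter), and in place of 4-ethoxyphenyl it gives an at least 2.7-fold lower number from compound 1 to compound 3 (0.43 log units; beyond the scatter). Going by these compounds alone, compound 3 thus supplies the first value that is a number rather than a limit of the assay, with the change running towards stronger inhibition, while the step from compound 1 to compound 2 cannot be read. Before this result, the series offered only one shared point, and that point still holds for the other two compounds: the limit of > 50000 nM in this assay, at which 2 of the 3 values shown sit.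

The compounds shown do not separate the contribution of the three chlorine atoms from that of their arrangement on the ring, since compound 3 differs from compound 1 and compound 2 in both at once. As far as these compounds go, how an unsubstituted phenyl, a phenyl with a single chlorine or a phenyl bearing an amine would read at this position remains open, as does whether any such group would go further than 2,4,6-trichlorophenyl.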